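This account rests on a few compounds, and the source may have more. Where it says the series, first, only, none or still open, it means among the compounds named here.

Compound 1, `O=C(Nc1cc(F)cc(Oc2cccnc2)c1)c1ccc(F)cc1`, is the amide of the pair, and in a physicochemical assay for solubility, measured as kinetic solubility (a lower number here means a less soluble compound, a higher number a more soluble compound), compound 1 gives 5.3 ug/mL. Compound 2, `COc1ccc(NC(=O)Nc2cc(F)cc(Oc3cccnc3)c2)cc1`, is the urea carrying a 4-methoxyphenyl group on an amide-type nitrogen. In this assay compound 2 returns only a limit, < 1 ug/mL. Compound 2 therefore sits at the limit of < 1 ug/mL in this assay, at which 1 of the 2 values shown sits, so its solubility is not known as a number, and the gap between compound 2 and compound 1 cannot be sized beyond saying that compound 1 stands above that limit. Compound 3, `O=C(Nc1cccnc1)Nc1cc(F)cc(Oc2cccnc2)c1`, has not yet been measured. It differs from compound 2 in one place: pyridin-3-yl in place of 4-methoxyphenyl on an amide-type nitrogen. Within the data shown here, no step between two measured compounds matches this change, so its size has to be estimated rather than read off. The replacement is expected to lift solubility by a modest step of an at least 3.0-fold higher number from compound 2 to compound 3 (0.47 log units; beyond the scatter), though with compound 2 at a limit the starting point itself is uncertain. For compound 3 the estimate in this assay is 3 ug/mL, with a range from 0.7 ug/mL to 15 ug/mL, and a real chance that this assay again reports only a limit.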

Compound 3, solubility: 46 ug/mL
For compound 3 the middle estimate is 15-fold (1.19 log units) below the measured one, outside the stated range (above it).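

In this assay, pyridin-3-yl in place of 4-methoxyphenyl on the amide-type nitrogen gives a urea with a measured number rather than a limit, and the change amounts to an at least 46-fold higher number from compound 2 to compound 3 (1.66 log units; beyond the scatter). Compound 2 gives a limit and not a number, so the full size of this step cannot be told: the limit of < 1 ug/mL in this assay, at which 1 of the 3 values shown sits. The urea is also not tied to a low reading, since (pyridin-3-yl)amino in place of 4-fluorophenyl on the carbonyl carbon gives an 8.7-fold higher number from compound 1 to compound 3 (0.94 log units; beyond the scatter), which puts the urea compound 3 above the amide compound 1.

That last step changes the linkage and the ring together, so the compounds shown do not tell how much of it belongs to each, and how pyridin-3-yl would read directly on the carbonyl carbon of the amide remains open. From the compounds shown here alone, it is also open how this assay would read with a morpholine or a carboxylic acid on the aromatic ring in the place held by pyridin-3-yl, and whether either would go beyond compound 3.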